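This account rests on a few compounds, and the source may have more. Where it says the series, first, only, none or still open, it means among the compounds named here.

In a functional assay on MV4-11 cells (Homo sapiens) for antiproliferative activity, read by luminescence, with a stated time of 72 h (a lower number here means a stronger inhibitor, a higher number a weaker inhibitor), both values so far are limits of the assay, not numbers:

Compound 1 `COc1cc(O)c(C(=O)OC(C)C)c(/C=C/CNC(C)=O)c1` gives > 10000 nM
Compound 2 `CCN(CC)C/C=C/C(=O)NC/C=C/c1cc(OC)cc(O)c1C(=O)OC(C)C` gives > 10000 nM

Compound 2 therefore offers no number to start from, only the limit of > 10000 nM in this assay, at which 2 of the 2 values shown sit, as its standing. Compound 3 `CCN(CC)C/C=C/C(=O)NC/C=C/c1cc(OCCc2ccc(F)cc2)cc(O)c1C(=O)OC(C)C` keeps compound 2 intact except at one place, where the change is 4-fluorobenzyl in place of hydrogen on a saturated chain carbon bound to an oxygen on an aromatic ring and methoxy becomes 2-(4-fluorophenyl)ethoxy. Within the data shown here, the sole measured step is a step that the two limits leave unreadable from compound 1 to compound 2 and it lies at a different place, so no measured step sizes this change. Any readable shift in this assay could only run toward stronger inhibition, though compound 3 may well remain at the limit. The expected at least 2.0-fold lower number from compound 2 to compound 3 (0.30 log units; that floor lies within the scatter) is therefore modest and very uncertain. For compound 3 the estimated value is 5000 nM and is expected to fall between 1000 nM and 20000 nM.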

Compound 3, half-maximal inhibitory concentration: 4040 nM
Beside the measured number, compound 3's estimate is 1.2-fold (0.09 log units) above it; the measured number falls inside the stated range.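

Extending methoxy to 2-(4-fluorophenyl)ethoxy gives an at least 2.4-fold lower number from compound 2 to compound 3 (0.39 log units; beyond the scatter) in this assay. This is the first change among the compounds shown that can be read, and it shows that activity in this assay responds to substitution on the saturated chain carbon bound to an oxygen on an aromatic ring, here with 4-fluorobenzyl in place of hydrogen. The step is only a floor because compound 2 stands at a limit of the assay: the limit of > 10000 nM in this assay, at which 2 of the 3 values shown sit.

On these data alone, the earlier step from compound 1 to compound 2 cannot be read, so what the 3-(diethylamino)prop-1-en-1-yl group contributes to compound 3 remains open. The compounds shown also do not tell whether the fluorine is needed, or how an unsubstituted phenyl, an amine or a longer chain at this place would compare.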